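Chain-lengthened hydroxamate analogue of compound 1

The source may hold more compounds than are shown below. What is called first, only, known or untested is meant among the compounds shown, and "the series" means these compounds.

Compound 1 `Nc1nc2cc(-c3nn(CCCCCC(=O)NO)c4ncnc(N)c34)ccc2o1` carries the only numerical result in the set: in a functional assay on MCF7 cells (Homo sapiens) for inhibition, read by MTT assay, with a stated time of 72 h (on this read-out lower numbers stand for stronger inhibition and higher numbers for weaker inhibition), compound 1 gives 12400 nM. Compound 2 `Nc1ncnc2c1c(-c1cnc3[nH]ccc3c1)nn2CCCCCC(=O)NO` reaches only (the limit of > 150000 nM in this assay, at which 1 of the 2 values shown sits), a limit of the assay and not a number, so in this assay compound 2 gives > 150000 nM. Compound 3 `Nc1nc2cc(-c3nn(CCCCCCC(=O)NO)c4ncnc(N)c34)ccc2o1` is not yet measured; it differs from compound 1 by (hydroxycarbamoyl)methyl in place of hydroxycarbamoyl on a saturated chain carbon, five bonds along the chain from an aromatic nitrogen. Going by the values given here, no measured step of this kind exists here, so the change is expected to shift this assay by little, a slight gain at most, close to the scatter. Compound 3 is therefore expected to give 8000 nM, between 3000 nM and 25000 nM, a step of a 1.6-fold lower number from compound 1 to compound 3 (0.19 log units; within the scatter).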

Compound 3, half-maximal inhibitory concentration: 11900 nM
The estimate for compound 3 lay 1.5-fold (0.17 log units) below the measured number, within the range that was stated.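

In this assay, the chain now has its first measured step, with (hydroxycarbamoyl)methyl in place of hydroxycarbamoyl on a saturated chain carbon, five bonds along the chain from an aromatic nitrogen: a 1.0-fold lower number from compound 1 to compound 3 (0.02 log units; within the scatter). On the core of compound 1, this read-out therefore does not separate these two chain lengths. Nothing shown bears on a cause for this result.

From the compounds shown here alone, whether a still longer chain or a shorter chain would also stay within the scatter remains open. So does the effect of a carboxylic acid or a primary amide in place of the hydroxamic acid end.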